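From Methoxy to Cyclopropylamino on the Shared Core

The source may hold more compounds than are shown below. What is called first, only, known or untested is meant among the compounds shown, and "the series" means these compounds.

In an ADME assay on PBMC cells (Homo sapiens) for cytotoxicity, read by MTT assay, with a stated time of 4 days (on this read-out lower numbers stand for higher toxicity in this test and higher numbers for lower toxicity in this test), compound 1 (`Nc1ncnc2c1ncn2[C@H]1CO[C@@H](CO)O1`) gives > 100000 nM and this value is a limit. In this assay compound 2 (`COc1ncnc2c1ncn2[C@H]1CO[C@@H](CO)O1`) gives > 100000 nM and this value is also a limit, so compound 2 stands without an exact number. Compound 3 (`OC[C@@H]1OC[C@H](n2cnc3c(NC4CC4)ncnc32)O1`) carries cyclopropylamino in place of methoxy on an aromatic carbon. Among the measured compounds shown here, the one measured step that bears on this change is a step that the two limits leave unreadable from compound 1 to compound 2 with methoxy in place of amino on an aromatic carbon. The record so far is the limit of > 100000 nM in this assay, at which 2 of the 2 values shown sit, and it gives no readable size or direction. No change beyond the scatter is therefore expected in this assay and the estimated step is a number no higher from compound 2 to compound 3 (the limit leaves the size open) under that expectation. For compound 3 the estimate is 100000 nM with an expected range from 30000 nM to 200000 nM in this test.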

Compound 3, half-maximal cytotoxic concentration: > 100000 nM
Compound 3: no number, only a limit; the forecaster's own chance of this, stated with the estimate: 75%; the middle value sits exactly at the limit.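

In this assay compound 3 gives > 100000 nM, which is a limit. Among the compounds shown here, no step among compound 1, compound 2 and compound 3 can be read: the limit of > 100000 nM in this assay, at which 3 of the 3 values shown sit. The compounds shown leave open whether amino, methoxy or cyclopropylamino on the shared core makes any difference in this assay.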